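A few compounds are considered here, and "the series" means these few. Any claim that something is new, unique, unknown or untested is made for them only; others in the source may bear on it.

Measured compounds:
Compound 1, `Oc1cccc(-c2cc(-c3ccsc3)cc(-c3ccccc3O)n2)c1`, gives 10.2%.
Compound 2, `Oc1ccc(-c2cc(-c3ccsc3)cc(-c3ccccc3O)n2)cc1`, gives 13.8%.
Compound 3, `Oc1ccc(-c2cc(-c3cccnc3)cc(-c3cccc(O)c3)n2)cc1`, gives 5.9%.

All three numbers come from an assay on isolated protein for inhibition of DNA topoisomerase 1 (Homo sapiens), with a stated time of 30 min, tested at 100 uM; on this read-out lower numbers stand for a weaker effect and higher numbers for a stronger effect at the one concentration tested. Compound 1 and compound 2 share one core and differ in a single group: 4-hydroxyphenyl in place of 3-hydroxyphenyl on an aromatic carbon. That change produced a number 3.6 percentage points higher from compound 1 to compound 2 (within the scatter), so the two values cannot be told apart with confidence. Compound 3 has the lowest number of the three, but its gaps to compound 1 and to compound 2 also lie within the scatter, so none of the three can be called stronger or weaker than another. The difference between the core of compound 3 and the core of compound 1 is not broken down here.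

Compound 4, `Oc1ccc(-c2cc(-c3cccnc3)cc(-c3ccc(O)cc3)n2)cc1`, has not yet been measured. It relates to compound 3 as compound 2 relates to compound 1: 4-hydroxyphenyl in place of 3-hydroxyphenyl on an aromatic carbon. This is the same kind of change as the earlier one, not the same change, since the surroundings differ: in compound 1 the group sits meta to a 2-hydroxyphenyl group and meta to a thiophen-3-yl group, whereas in compound 3 it sits meta to a 4-hydroxyphenyl group and meta to a pyridin-3-yl group. Because the earlier step was a number 3.6 percentage points higher from compound 1 to compound 2 (within the scatter), a step of similar small size is expected here, a number 3.6 percentage points higher from compound 3 to compound 4 (within the scatter), resting on that one earlier pair alone. Compound 4 is therefore expected to give about 9.5% in this assay, with a likely range from 0% to 20%.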

Compound 4, a percentage reported as inhibition, at one concentration (the size of the read-out at that concentration, not a potency): 8.7%
Compound 4: middle estimate off by 0.8 percentage points, on the high side; low and high end bracket the measured number.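

On the core of compound 3, putting 4-hydroxyphenyl in place of 3-hydroxyphenyl in this assay gave a number 2.8 percentage points higher from compound 3 to compound 4 (within the scatter), and this step agrees with the one seen earlier: the same change on two cores in this assay, a number 3.6 percentage points higher (within the scatter) from compound 1 to compound 2 and a number 2.8 percentage points higher (within the scatter) from compound 3 to compound 4, 0.8 percentage points apart, within the scatter of two such steps

So across these two cores, the swap behaves alike: each time the step is small and cannot be told apart from the ordinary spread of repeated measurements, even though the neighbouring groups on the two cores differ. This does not show that 4-hydroxyphenyl gives a stronger effect than 3-hydroxyphenyl, nor that the agreement would hold on a third core, and a reading at one concentration is not a measure of potency.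

The compounds shown leave open whether any other group at this place, such as an aminophenyl group, a methoxyphenyl group or a carboxylic acid, would give a number clearly apart from those seen so far. They also leave open how the pyridin-3-yl and thiophen-3-yl groups compare on their own, since the core of compound 1 and the core of compound 3 differ in more than one place.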